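The source may report more compounds than this note shows. Statements on the series, on what has been measured and on what is new or still open speak of the compounds shown alone.

Measured so far in a functional assay on the whole organism with Scenedesmus acutus as the target, read by spectrophotometry; on this read-out lower numbers stand for stronger inhibition and higher numbers for weaker inhibition:
- compound 1, `S=c1s/c(=N\c2ccc(Br)cc2)n2n1CCCC2`: 148 nM
- compound 2, `CC(C)Oc1cc(/N=c2\sc(=S)n3n2CCCC3)c(F)cc1Cl`: 11.2 nM

Compound 2 holds the lowest of the two numbers in this assay. Within the data shown here, compound 1, its only neighbour on the shared core, gives the higher number, and the gap between the two lies beyond the usual scatter of repeated measurements, so compound 2 is the stronger inhibitor of the pair. The two compounds differ in several places at once, so their values show only where each stands, not what any single change does.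

Compound 3, `C#CCOc1cc(/N=c2\sc(=S)n3n2CCCC3)c(F)cc1Cl`, keeps everything of compound 2 except one group: propargyl in place of isopropyl on an oxygen on an aromatic ring. Among the measured compounds shown here, no pair of measured compounds shows this change, so there is no measured step to lean on. The expected step in this assay from compound 2 to compound 3 is small, a 1.4-fold higher number from compound 2 to compound 3 (0.15 log units; within the scatter), likely within the scatter and, if anything, slightly toward a higher number. The expected value for compound 3 is 16 nM, with a range from 5 nM to 50 nM.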

Compound 3, half-maximal inhibitory concentration: 5.5 nM
Compound 3: the middle estimate sits 2.9-fold (0.46 log units) above what was measured; measured number inside the range.
By their numbers in this assay, from the lowest: compound 3; then compound 2; then compound 1.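

In this assay, propargyl in place of isopropyl on an oxygen on an aromatic ring gives a 2.0-fold lower number from compound 2 to compound 3 (0.31 log units; beyond the scatter), a modest step and the only change in a single place among the compounds shown. The oxygen substituent therefore has a measurable effect on the read-out: two groups of the same size by count, 3 carbon heavy atoms each and neither with a ring, are told apart, and the one that carries the triple bond gives the lower number. No measurement at hand bears on what lies behind this step.

Going by these compounds, a single pair gives a direction for this one exchange and no trend, so it remains open whether an allyl group, a longer chain or a benzyl group on the same oxygen would extend the step, and whether a free hydroxyl would reverse it. Also open, on these data alone, is what the chloro and fluoro groups on the aromatic ring each contribute, as compound 1 differs from compound 2 in several places at once.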